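Swapping the aryl ether group and watching acid dissociation

The source may hold more compounds than are shown below. What is called first, only, known or untested is meant among the compounds shown, and "the series" means these compounds.

Compound 1, `CC(C)(C)c1ccc(Oc2ccc3c(NCCCNCc4ccco4)ccnc3c2)cc1`, gives 9.28 in a physicochemical assay for acid dissociation.
Compound 2, `COc1ccc(Oc2ccc3c(NCCCNCc4cc(F)ccc4OC)ccnc3c2)cc1`, gives 9.28 in this assay.
Compound 3, `CCC(CC)c1ccc2c(NCCCNCc3cc(F)ccc3OC)ccnc2c1`, gives 9.47 in this assay.

Compound 1 sits level with compound 2 at the digits shown, the two together lowest of the three numbers; compound 3 lies a number 0.19 log units higher from compound 2 to compound 3 (within the scatter), a difference that stays within the scatter. Compound 4, `CN(C)c1cccc(Oc2ccc3c(NCCCNCc4ccco4)ccnc3c2)c1`, differs from compound 1 by 3-(dimethylamino)phenyl in place of 4-(tert-butyl)phenyl on an oxygen on an aromatic ring. Going by the values given here, no measured step changes the group on that ether oxygen, and the one step known, a number 0.19 log units higher from compound 2 to compound 3 (within the scatter), altered another part of the shared core without moving the number beyond the scatter. So no shift beyond the scatter is expected in this assay: compound 4 is estimated at 9.28, between 8.95 and 9.65, meaning no change at the digits printed from compound 1 to compound 4 (within the scatter).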

Compound 4, acid dissociation constant: 9.28
For compound 4 middle estimate and measured number coincide at the digits printed; measured number inside the range.
By their numbers in this assay, from the lowest: compounds 1, 2, 4 and 3 (each within the scatter of the next).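

In this assay, going by these compounds alone, the only step that changes the group on the ether oxygen reads no change at the digits printed from compound 1 to compound 4 (within the scatter) when 3-(dimethylamino)phenyl replaces 4-(tert-butyl)phenyl. This position therefore tolerates this swap without a shift beyond the scatter, even though the entering group carries a nitrogen and a hydrogen-bond acceptor that the leaving group lacks. No supporting measurement is available to explain this result.

The compounds shown leave open whether a carboxylic acid on that aromatic ring would move the number beyond the scatter. The same question stands for a simple ethyl chain in place of the ring on that oxygen.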